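A few compounds are considered here, and "the series" means these few. Any claim that something is new, unique, unknown or untested is made for them only; others in the source may bear on it.

The study concerns amides built on a shared core, each examined in an ADME assay on Raji cells (Homo sapiens) for cytotoxicity, read by CellTiter-Glo and resazurin assay, with a stated time of 72 h; on this read-out lower numbers stand for an effect already at smaller amounts and higher numbers for an effect only at larger amounts of compound. Compound 1 `CC(C)Oc1cccc(-c2ccc(C(=O)N(Cc3cccc(OCCCCCC(=O)O)c3)C(C)C)cc2)c1` is the parent of the set. In this assay compound 1 reaches only the limit of the assay, > 26000 nM. Compound 2 `CC(C)N(Cc1cccc(OCCCCCC(=O)O)c1)C(=O)c1ccc(-c2cccc(OC(F)(F)F)c2)cc1` carries trifluoromethyl in place of isopropyl on an oxygen on an aromatic ring, and in this assay compound 2 also gives only a limit, > 26000 nM. Compound 3 `CCOC(=O)CCCCCOc1cccc(CN(C(=O)c2ccc(-c3cccc(OC(C)C)c3)cc2)C(C)C)c1` has ethyl in place of hydrogen on an oxygen next to a carbonyl group, and in this assay compound 3 likewise shows only a limit, > 26000 nM. The two measured steps, a step that the two limits leave unreadable from compound 1 to compound 2 and a step that the two limits leave unreadable from compound 1 to compound 3, are therefore of unreadable size, all three values sitting at the limit of > 26000 nM in this assay, at which 3 of the 3 values shown sit.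

Compound 4 `CCOC(=O)CCCCCOc1cccc(CN(C(=O)c2ccc(Br)cc2)C(C)C)c1` differs from compound 3 by bromo in place of 3-isopropoxyphenyl on an aromatic carbon. Among the compounds with values here, no measured step removes a whole aryl group, so nothing points to a shift. Compound 4 is expected to remain at the limit, estimated at 40000 nM with a range from 15000 nM to 110000 nM. Compound 4 is accordingly expected to show a step that the limit leaves unreadable from compound 3 to compound 4, within the scatter.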

Compound 4, half-maximal effective concentration: > 26000 nM
Compound 4 ended at the assay's limit; the forecaster's own chance of this, stated with the estimate: 85%; the middle value lies beyond the limit too.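

In this assay, within the data shown here, compound 4 gives > 26000 nM as a limit of the assay, so no step from compound 3 to compound 4 can be read. The compounds shown leave open at what concentration any of them would reach a half-maximal effect in this assay and whether these changes alter it.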